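The source may report more compounds than this note shows. Statements on the series, on what has been measured and on what is new or still open speak of the compounds shown alone.

Compound 1, `CS(=O)(=O)c1ccc(C(=O)N2CCC(C(=O)N(Cc3ccccc3)Cc3ccccc3)CC2)cc1[N+](=O)[O-]`, gives > 60000 nM in an assay on isolated protein for inhibition of vitamin D3 receptor (Homo sapiens), read by fluorescence polarization (on this read-out higher numbers stand for weaker inhibition and lower numbers for stronger inhibition), which is a limit of the assay.
Compound 2, `CS(=O)(=O)c1ccc(C(=O)N2CCC(C(=O)N3CCc4ccccc4C3)CC2)cc1[N+](=O)[O-]`, gives > 60000 nM in this assay, again a limit.
Compound 3, `CN(CC(=O)N1CCc2ccccc2C1)C(=O)c1ccc(S(C)(=O)=O)c([N+](=O)[O-])c1`, gives > 60000 nM in this assay, also a limit.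

Compound 2 therefore stands where every other measured compound stands: at the limit of > 60000 nM in this assay, at which 3 of the 3 values shown sit. No number for it is known, only that its inhibition is too weak for the assay to put a figure on.

Compound 4, `CC(C)N(C(=O)C1CCN(C(=O)c2ccc(S(C)(=O)=O)c([N+](=O)[O-])c2)CC1)C(C)C`, has not been measured. It differs from compound 2 in one place: diisopropylamino in place of 1,2,3,4-tetrahydroisoquinolin-2-yl on a carbonyl carbon

Among the measured compounds shown here, since no pair of measured compounds differs in a single place, no measured step shows how large a change of this kind might be. The three measured compounds share the same core and vary in the amide part, and all three sit at the limit, so the expected step from compound 2 to compound 4 is none beyond the scatter, a number no higher from compound 2 to compound 4 (the limit leaves the size open), and compound 4 is most likely to end at the same limit.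

For compound 4 the expected value in this assay is 60000 nM, within 20000 nM to 200000 nM.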

Compound 4, half-maximal inhibitory concentration: > 60000 nM
Compound 4 gave a limit, no number (the forecaster's own chance of this, stated with the estimate: 80%); the middle value sits exactly at the limit.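

Among the compounds shown here, compound 2 and compound 4 both give a limit in this assay rather than a number, so no step between them can be read. The compounds shown leave open whether any change in the amide part would give a measurable value in this assay.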